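A few compounds are considered here, and "the series" means these few. Any claim that something is new, unique, unknown or untested is made for them only; others in the source may bear on it.

- compound 1 `O=C(NCCCCc1ccccc1)c1cccc(C2SCC(=O)N2c2ccccc2)c1` measured at 15.9 nM
- compound 2 `O=C(NCCCCc1ccccc1)c1cccc(C2SCC(=O)N2c2ccccn2)c1` measured at 19.7 nM

For the measured compounds named here, in a functional assay on HOS-TE85 cells (Homo sapiens) for inhibition, read by CCK-8 assay, with a stated time of 72 h (a lower number here means a stronger inhibitor, a higher number a weaker inhibitor), compound 2 gives 19.7 nM and lies within the scatter of compound 1, the only other measured compound, so the two cannot be separated. Compound 3 `C#Cc1cccc(N2C(=O)CSC2c2cccc(C(=O)NCCCCc3ccccc3)c2)c1` has not yet been measured and carries 3-ethynylphenyl in place of pyridin-2-yl on an amide-type nitrogen in a ring, a change counted as 3-ethynylphenyl in place of pyridin-2-yl on an amide-type nitrogen in a ring in full. Going by the values given here, one measured step bears on this place, namely a 1.2-fold higher number from compound 1 to compound 2 (0.09 log units; within the scatter) for pyridin-2-yl in place of phenyl. Among the compounds with values here, no measured compound carries the 3-ethynylphenyl group, so the data give no direction for it. Within the data shown here, with a 1.2-fold higher number from compound 1 to compound 2 (0.09 log units; within the scatter) as the only guide, no step beyond the scatter is expected in this assay in either direction, though the range is kept wide. The estimate means an expected 1.1-fold higher number from compound 2 to compound 3 (0.05 log units; within the scatter) at most in size. Compound 3 is expected at 22 nM with an estimated range from 7 nM to 70 nM for its value.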

Compound 3, half-maximal inhibitory concentration in the HOS-TE85 assay: 149 nM
Compound 3: middle estimate off by 6.8-fold (0.83 log units), on the low side; the measured number lies above the stated range.
By their numbers in the HOS-TE85 assay, from the lowest: compounds 1 and 2 (each within the scatter of the next); then compound 3.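

For the compounds shown here, in the HOS-TE85 assay the position on the amide-type nitrogen in a ring, which showed no separable difference between phenyl and pyridin-2-yl, now responds to a substituent: compound 3 gives 149 nM, with 3-ethynylphenyl in place of pyridin-2-yl giving a 7.6-fold higher number from compound 2 to compound 3 (0.88 log units; beyond the scatter) and ethynyl in place of hydrogen on an aromatic carbon giving a 9.4-fold higher number from compound 1 to compound 3 (0.97 log units; beyond the scatter) as the single change from the phenyl compound. In a physicochemical assay for solubility, read by turbidimetry, measured as kinetic solubility, at pH 7.4 (a lower number here means a less soluble compound, a higher number a more soluble compound), compound 2 gives 20000 nM and compound 3 gives 10000 nM. In the physicochemical assay the same replacement gives a 2.0-fold lower number from compound 2 to compound 3 (0.30 log units; within the scatter) and so does not separate the two compounds. Nothing shown accounts for the weaker result in the cell assay.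

On these data alone, whether this drop is particular to ethynyl or would also come with a methyl, a chlorine or a nitrile on that aromatic carbon stays open. So does whether ethynyl would have the same effect on the pyridin-2-yl group.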